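This account rests on a few compounds, and the source may have more. Where it says the series, first, only, none or still open, it means among the compounds named here.

Compound 1 `O=C1/C(=C/c2ccccc2Br)Cc2ccccc21` was examined in a functional assay on P388 cells (Mus musculus) for inhibition; a lower number here means a stronger inhibitor, a higher number a weaker inhibitor. In this assay compound 1 gives only > 50000 nM, which is a limit of the assay rather than a measured number. Compound 1 therefore stands at the limit of > 50000 nM in this assay, at which 1 of the 2 values shown sits. Compound 2 `COc1ccccc1/C=C1\CCCc2ccccc2C1=O` carries a methoxy group and a different core; in this assay compound 2 gives 18000 nM, a weak inhibition. Among the measured compounds shown here, compound 1 and compound 2 differ in more than one place, so no single step between measured compounds can be read from them. Compound 3 `Cc1ccccc1/C=C1\Cc2ccccc2C1=O` has not yet been measured. It differs from compound 1 by methyl in place of bromo on an aromatic carbon. Since compound 1 already sits at the limit, the expected step from compound 1 to compound 3 an at least 1.2-fold lower number from compound 1 to compound 3 (0.09 log units; that floor lies within the scatter) is small, with no change beyond the usual scatter expected. For compound 3 the estimate in this assay is 40000 nM, within a range from 10000 nM to 150000 nM, and a result reported only as a limit is expected to remain quite possible.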

Compound 3, half-maximal inhibitory concentration: 23900 nM
Estimate against measurement, compound 3: 1.7-fold (0.22 log units) above; low and high end bracket the measured number.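

The change from bromo to methyl on an aromatic carbon, ortho to a large group, gives an at least 2.0-fold lower number from compound 1 to compound 3 (0.32 log units; beyond the scatter) in this assay and so shows that the group at this position matters for inhibition. Compound 2 differs from compound 1 in more than one place, so it could not show this for a single change. From the compounds shown here alone, the true size of the step remains unknown because the value for compound 1 is a limit, so the step is only a minimum: the limit of > 50000 nM in this assay, at which 1 of the 3 values shown sits.

Still open, going by these compounds, is how an unsubstituted ring, or a ring carrying an amine or a carboxylic acid at this same aromatic carbon, would compare with compound 3. Also open, on these data alone, is whether the same exchange of bromo for methyl would give a similar step on the core of compound 2.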